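The source may hold more compounds than are shown below. What is called first, only, known or untested is meant among the compounds shown, and "the series" means these compounds.

Of the compounds shown here, three built on one shared core have been measured in an assay for inhibition of Alpha amylase (Homo sapiens), with a stated time of 30 min; on this read-out higher numbers stand for weaker inhibition and lower numbers for stronger inhibition. Compound 1 `CCOC(=O)c1c(-c2ccccc2)nn(-c2ccccc2)c1COc1cc(OC)c(C=O)c(OC)c1` gives 40 ug/mL. Compound 2 `CCOC(=O)c1c(-c2ccccc2)nn(-c2ccccc2)c1COc1ccc(C=O)cc1OC` gives 60 ug/mL. Compound 3 `CCOC(=O)c1c(-c2ccccc2)nn(-c2ccccc2)c1COCc1ccccc1` gives 45 ug/mL, which places it second highest of the three numbers, though the step of a 1.1-fold higher number from compound 1 to compound 3 (0.05 log units; within the scatter) and the step of a 1.3-fold lower number from compound 2 to compound 3 (0.12 log units; within the scatter) both stay within the scatter, so compound 3 sits close to each of the others.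

Compound 4 `CCOC(=O)c1c(-c2ccccc2)nn(-c2ccccc2)c1COc1ccccc1C=O` has not yet been measured in this assay. It differs from compound 3 by 2-formylphenyl in place of benzyl on an oxygen on a saturated carbon. Among the measured compounds shown here, the steps that bear on this change are those that exchange the group on the same oxygen: a 1.1-fold higher number from compound 1 to compound 3 (0.05 log units; within the scatter), a 1.3-fold lower number from compound 2 to compound 3 (0.12 log units; within the scatter) and a 1.5-fold higher number from compound 1 to compound 2 (0.18 log units; within the scatter), none of which leaves the scatter. On that basis the step of a 1.1-fold higher number from compound 3 to compound 4 (0.05 log units; within the scatter) is expected to remain within the scatter, with no direction that can be called. Compound 4 is accordingly estimated at 50 ug/mL, with a range from 25 ug/mL to 100 ug/mL.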

Compound 4, half-maximal inhibitory concentration: 40 ug/mL
For compound 4 the middle estimate is 1.3-fold (0.10 log units) above the measured one, and the stated range covers the measured number.
By their numbers in this assay, from the lowest: compounds 1, 4, 3 and 2 (each within the scatter of the next).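

In this assay, the exchange at the oxygen on a saturated carbon again leaves the number within the scatter: the step of a 1.1-fold lower number from compound 3 to compound 4 (0.05 log units; within the scatter) brings in 2-formylphenyl for benzyl, the step of a 1.5-fold lower number from compound 2 to compound 4 (0.18 log units; within the scatter) brings it in for 4-formyl-2-methoxyphenyl, and the step of no change at the digits printed from compound 1 to compound 4 (within the scatter) brings it in for the group of compound 1. Among the compounds shown here, the simple 2-formylphenyl group therefore adds a fourth group at this place, and no pair among the four compounds separates beyond the scatter, whether or not a formyl group or a methoxy group is present. Nothing at hand explains this flat picture.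

All four groups carry a six-membered aromatic ring of carbon only. On these data alone, whether an amine, a carboxylic acid or a longer saturated chain in place of that ring would move the number beyond the scatter stays open.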